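A few compounds are considered here, and "the series" means these few. Any claim that something is new, unique, unknown or untested is made for them only; others in the source may bear on it.

Values in a functional assay on PC-3 cells (Homo sapiens) for antiproliferative activity, read by MTT assay, with a stated time of 72 h; a lower number here means a stronger inhibitor, a higher number a weaker inhibitor:
compound 1 `CCn1c(C(=O)NCCC(=O)O)ccc1C(CC)(CC)c1ccc(C#CC(O)(CC)CC)c(C)c1`: 5130 nM
compound 2 `CCn1cc(C(CC)(CC)c2ccc(C#CC(O)(CC)CC)c(C)c2)cc1C(=O)NCCCN(C)C`: 15100 nM

Compound 2, at 15100 nM, holds the higher of the two numbers, which makes it the weaker inhibitor of the pair. Its gap to compound 1, at 5130 nM, lies beyond the usual scatter.

The next compound to be read is compound 3 `CCn1cc(C(CC)(CC)c2ccc(C#CC(O)(CC)CC)c(C)c2)cc1C(=O)N[C@H](C(=O)O)C(C)C`. It carries 1-carboxy-2-methylpropyl in place of 3-(dimethylamino)propyl on an amide-type nitrogen.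

Among the compounds with values here, no measured pair differs in one place only, so the size of this step has little support. Compound 1 also bears a carboxy group and gives 5130 nM, and that single value is the only hint of direction. A small move to a lower number in this assay is therefore expected, at about the edge of the scatter. The estimated change is a 1.9-fold lower number from compound 2 to compound 3 (0.28 log units; within the scatter). For compound 3 the expected value is 8000 nM, with an estimated range of 3000 nM to 18000 nM.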

Compound 3, half-maximal inhibitory concentration: 3750 nM
Compound 3: middle estimate off by 2.1-fold (0.33 log units), on the high side; measured number inside the range.
By their numbers in this assay, from the lowest: compounds 3 and 1 (each within the scatter of the next); then compound 2.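

Working notes on the amide side chain: in this assay, exchanging 3-(dimethylamino)propyl for 1-carboxy-2-methylpropyl on the amide-type nitrogen gives a 4.0-fold lower number from compound 2 to compound 3 (0.60 log units; beyond the scatter), the first single-place comparison in the series, and it shows that the number responds to the group at this position. The exchange removes an amine and brings in a carboxy group, a branched chain and a defined stereocentre all at once, so the step belongs to the whole substituent and cannot be assigned to any one of these features. No measurement at hand bears on the reason for this step.

Open, going by these compounds, is whether the carboxy group or the branched chain carries the step; on the same core, a 2-methylpropyl chain without the carboxy group and an unbranched carboxyalkyl chain would separate the two. Also open, on these data alone, is the part played by the stereocentre, which the opposite configuration of 1-carboxy-2-methylpropyl would address, and whether a primary amine at the end of the propyl chain would read like the dimethylamino group.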